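Swapping a side chain for hydroxy near an assay limit

A few compounds are considered here, and "the series" means these few. Any claim that something is new, unique, unknown or untested is made for them only; others in the source may bear on it.

Among the compounds with values here, in an ADME assay on MDCK cells (Canis lupus familiaris) for cytotoxicity, read by MTT assay, with a stated time of 48 h (on this read-out lower numbers stand for higher toxicity in this test and higher numbers for lower toxicity in this test), compound 1 `COC(=O)[C@H](CC(C)C)NC(=O)CSc1nc(-c2ccccc2)cc(-c2ccc(C)cc2)c1C#N` gives 215000 nM as the only true number among the values available. Compound 2 `COC(=O)C[C@H](NC(=O)[C@@H](NC(=O)CSc1nc(-c2ccccc2)cc(-c2ccc(C)cc2)c1C#N)C(C)C)C(=O)OC` reads > 250000 nM as a limit of the assay and not a number. Compound 3 `COC(=O)C[C@H](NC(=O)[C@@H](NC(=O)CSc1nc(-c2ccccc2)cc(-c2ccc(C)cc2)c1C#N)C(C)C)C(=O)N[C@@H](CCSC)C(=O)OC` reads > 250000 nM as a limit too. These results meet the limit of > 250000 nM in this assay, at which 2 of the 3 values shown sit, and leave compound 1 close to that limit.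

Compound 4 `Cc1ccc(-c2cc(-c3ccccc3)nc(SCC(=O)O)c2C#N)cc1` carries hydroxy in place of (1-(methoxycarbonyl)-3-methylbutyl)amino on a carbonyl carbon. Within the data shown here, the only measured step is a step that the two limits leave unreadable from compound 2 to compound 3 and it offers no size to carry over to this change. With compound 1 at 215000 nM as the sole anchor, no step beyond the scatter is expected in this assay here. The estimated change is a 1.2-fold lower number from compound 1 to compound 4 (0.08 log units; within the scatter) and it is expected to stay small. For compound 4 the expected value is 180000 nM with an estimated range from 70000 nM to 250000 nM as the likely span.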

Compound 4, half-maximal cytotoxic concentration: > 250000 nM
Compound 4 ended at the assay's limit; the forecaster's own chance of this, stated with the estimate: 35%; middle value at least 1.3-fold (0.14 log units) away from the limit.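

In this assay compound 4 reads > 250000 nM, which is a limit of the assay and not a number. Putting hydroxy in place of (1-(methoxycarbonyl)-3-methylbutyl)amino on a carbonyl carbon gives an at least 1.1-fold higher number from compound 1 to compound 4 (0.06 log units; that floor lies within the scatter), so this floor does not establish a real rise, but the number does not fall when the whole chain and its defined stereocentre are gone. The earlier compounds all kept a chain at this carbonyl carbon, and the result now shows that a low-toxicity reading in this test does not depend on one, while any larger step stays hidden at the ceiling: the limit of > 250000 nM in this assay, at which 3 of the 4 values shown sit.

As far as these compounds go, whether a primary amide or a simple methyl ester on this carbonyl carbon would also reach the limit stays open. From the compounds shown here alone, compounds at the limit cannot be ranked against one another, and it also stays open whether any group here would clearly lower the number.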